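The source may report more compounds than this note shows. Statements on the series, on what has been measured and on what is new or still open speak of the compounds shown alone.

Working notes on the series. Going by the values given here, compound 1 `CN(C)CCn1cnnc1-c1cc(Oc2ccc(NC(=O)N/N=C/c3cc(C(C)(C)C)cc(C(C)(C)C)c3O)cc2F)ccn1` is the only member with a number in an ADME assay on WI-38 cells (Homo sapiens) for cytotoxicity, read by MTT assay, with a stated time of 72 h; on this read-out higher numbers stand for weaker inhibition and lower numbers for stronger inhibition: compound 1 gives 2350 nM. Compound 2 `COc1ccc(/C=N/NC(=O)Nc2ccc(Oc3ccnc(-c4nncn4CCN(C)C)c3)c(F)c2)c(OC)c1OC` carries a 2,3,4-trimethoxyphenyl group on the carbon with a double bond to nitrogen; in this assay compound 2 gives "not determined" (no result reported), so compound 2 stands at no single number. Compound 3 `CN(C)CCn1cnnc1-c1cc(Oc2ccc(NC(=O)N/N=C/c3c(O)ccc4ccccc34)cc2F)ccn1` is the step from compound 2: 2-hydroxynaphthalen-1-yl in place of 2,3,4-trimethoxyphenyl on a carbon with a double bond to nitrogen. Among the compounds with values here, no measured pair differs in one place, so nothing in the data fixes the size of this step in this assay; a shift in either direction within the usual scatter is as likely as none, and a larger move cannot be excluded. Compound 3 is expected to land near 3000 nM (range 800 nM to 12000 nM). The anchor for this expectation is compound 1, which gives 2350 nM in this assay.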

Compound 3, half-maximal inhibitory concentration: 3250 nM
Compound 3: middle estimate off by 1.1-fold (0.03 log units), on the low side; low and high end bracket the measured number.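

No new step can be read from compound 2 and compound 3 in this assay on the figures at hand. Going by these compounds, how 2-hydroxynaphthalen-1-yl compares with 2,3,4-trimethoxyphenyl at this place stays open. Nothing at hand bears on the cause of any value here.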